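A few compounds are considered here, and "the series" means these few. Any claim that something is new, unique, unknown or untested is made for them only; others in the source may bear on it.

In a functional assay on T47D cells (Homo sapiens) for cytotoxicity, read by CCK-8 assay and cell counting, with a stated time of 72 h (a higher number here means a weaker inhibitor, a lower number a stronger inhibitor), three compounds have been measured so far:

Compound 1 `COc1cc(OC)cc(-c2cc3ccccc3c(-c3cccc(O)c3)n2)c1` gives 760 nM.
Compound 2 `COc1cc(OC)cc(-c2cc3ccccc3c(-c3cccc(N)c3)n2)c1` gives 980 nM.
Compound 3 `COc1ccc(-c2cc3cc(C)ccc3c(-c3cccc(O)c3)n2)c(C)c1` gives 560 nM.

Compound 2 differs from compound 1 by one change, (amino in place of hydroxy on an aromatic carbon). The step it made in this assay is a 1.3-fold higher number from compound 1 to compound 2 (0.11 log units; within the scatter), so the two values cannot be told apart. Compound 3 carries a different core; the difference between the two cores is not broken down here. Its value sits among the others within the usual scatter, so no order among the three is claimed.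

Compound 4 `COc1ccc(-c2cc3cc(C)ccc3c(-c3cccc(N)c3)n2)c(C)c1` has not been measured. It differs from compound 3 by amino in place of hydroxy on an aromatic carbon, the same change that links compound 1 to compound 2. Because the earlier step was a 1.3-fold higher number from compound 1 to compound 2 (0.11 log units; within the scatter), the step from compound 3 to compound 4 in this assay is expected to be of the same small kind, a 1.3-fold higher number from compound 3 to compound 4 (0.10 log units; within the scatter). Compound 4 is therefore estimated at 700 nM, with a range from 400 nM to 1300 nM expected.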

Compound 4, half-maximal inhibitory concentration: 740 nM
Beside the measured number, compound 4's estimate is 1.1-fold (0.02 log units) below it; low and high end bracket the measured number.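

In this assay the exchange of 3-hydroxyphenyl for 3-aminophenyl on the core of compound 3 gave the step (a 1.3-fold higher number from compound 3 to compound 4 (0.12 log units; within the scatter)) and, set beside the step on the other core, it reads the same: the same change on two cores in this assay, a 1.3-fold higher number (0.11 log units; within the scatter) from compound 1 to compound 2 and a 1.3-fold higher number (0.12 log units; within the scatter) from compound 3 to compound 4, 1.0-fold (0.01 log units) apart, within the scatter of two such steps

Within these two pairs, then, the change carries from one core to the other with no difference that can be detected. Going by these compounds alone, this does not show that the change does anything to the number, since each step on its own lies within the scatter, so the agreement is one between two steps that cannot be told from no step at all; and two cores are too few to support a rule for the whole series.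

On these data alone, it remains open whether another group on that aromatic carbon, such as a fluorine, an acetamide or a carboxylic acid, would shift the number beyond the scatter. Also open is which of the differences between the two cores matter, as no pair shown separates them.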